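The source may hold more compounds than are shown below. What is called first, only, known or untested is meant among the compounds shown, and "the series" means these compounds.

Measured so far:
- compound 1, `N#Cc1ccc(S(=O)(=O)NNc2ccc(Br)cc2)cc1` — in an assay on HeLa cells for inhibition of Indoleamine 2,3-dioxygenase 1 (Homo sapiens), read by spectrophotometry, with a stated time of 24 h (on this read-out lower numbers stand for an effect already at smaller amounts and higher numbers for an effect only at larger amounts of compound), compound 1 gives 134 nM
- compound 2, `O=C(O)COc1ccc(S(=O)(=O)NNc2ccc(Br)cc2)cc1` — in this assay compound 2 gives 152 nM

Among the measured compounds shown here, compound 2 and compound 1 sit within the scatter of one another; the single step on the aromatic carbon of the shared core, a 1.1-fold higher number from compound 1 to compound 2 (0.05 log units; within the scatter), is within the scatter. So far, then, exchanging one group for another at this position has moved nothing that can be separated from repeat variation.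

Compound 3, `O=C(O)c1ccc(S(=O)(=O)NNc2ccc(Br)cc2)cc1`, is not yet measured. The change from compound 2 is carboxy in place of carboxymethoxy on an aromatic carbon. For the measured compounds named here, the only step that bears on it is the one from compound 1 to compound 2, at the same position, which stayed within the scatter. On that basis no step beyond the scatter is expected in this assay for compound 3 either. The expected step is a 1.0-fold lower number from compound 2 to compound 3 (0.01 log units; within the scatter), within the scatter. Compound 3 is therefore estimated at 150 nM, with a range from 70 nM to 330 nM.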

Compound 3, half-maximal effective concentration: 172 nM
Beside the measured number, compound 3's estimate is 1.1-fold (0.06 log units) below it, and the stated range covers the measured number.
By their numbers in this assay, from the lowest: compounds 1, 2 and 3 (each within the scatter of the next).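

In this assay the two new steps are a 1.1-fold higher number from compound 2 to compound 3 (0.05 log units; within the scatter) and a 1.3-fold higher number from compound 1 to compound 3 (0.11 log units; within the scatter) and both stay within the scatter. This position on the aromatic carbon now holds cyano, carboxymethoxy and carboxy, and the shorter carboxy separates from neither of the other two, so removing the chain atoms of carboxymethoxy does not shift the number measurably, and the same holds for exchanging cyano for carboxy. No measurement shown offers any account of why the number stays put across these groups.

The compounds leave open whether an amine, a primary amide or a longer chain ending in a carboxylic acid at this position would produce a step beyond the scatter. They also leave open what chlorine or methyl would do in place of the bromine that all three compounds share.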